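From Isopropyl to Propyl on a Weak Agonist

This account rests on a few compounds, and the source may have more. Where it says the series, first, only, none or still open, it means among the compounds named here.

Within the data shown here, compound 1, `CCN(Cc1cccs1)C(=O)COc1ccc(C(C)C)cc1`, sits at the top of the three numbers so far. In an assay on HEK293 cells for agonist activity at transient receptor potential cation channel subfamily M member 8 (Homo sapiens), read by fluorescence and calcium flux, with a stated time of 15 min (a lower number here means that less compound is needed, a higher number that more compound is needed for the effect), compound 1 gives 397 nM, the highest of the set. Compound 2, `CCN(Cc1cccs1)C(=O)/C=C/c1ccc(C)cc1`, gives 2 nM in this assay, a number far lower than that of compound 1 and outside the usual scatter. Compound 3, `O=C(COc1ccc2c(c1)CCC2)N(Cc1cccs1)c1ccn[nH]1`, gives 0.001 nM in this assay, lower still and again well beyond the scatter from compound 1. Neither comparison is a single-point change, so they show only how far compound 1 lags.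

Compound 4, `CCCc1ccc(OCC(=O)N(CC)Cc2cccs2)cc1`, has not been measured. It differs from compound 1 in one place: propyl in place of isopropyl on an aromatic carbon. The same atoms are present, joined differently, and no ring, donor, acceptor or charge changes.

Among the measured compounds shown here, no step between measured compounds isolates such a rearrangement, so there is no direct guide. A swap of this kind, on an aromatic carbon para to a large group, is expected to move the number little in this assay, in no firm direction and probably not beyond the scatter. Compound 4 is therefore estimated at 400 nM, with a range of 150 nM to 1200 nM, meaning an expected step of a 1.0-fold higher number from compound 1 to compound 4 (0.00 log units; within the scatter).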

Compound 4, half-maximal effective concentration: 1810 nM
Estimate against measurement, compound 4: 4.5-fold (0.66 log units) below; measured number outside the range, above it.
By their numbers in this assay, from the lowest: compound 3; then compound 2; then compound 1; then compound 4.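

Among these compounds, this is the first step in the set that changes one place alone, and it shows that the position on an aromatic carbon para to a large group is sensitive to how its three carbons are joined: in this assay, propyl in place of isopropyl gives a 4.6-fold higher number from compound 1 to compound 4 (0.66 log units; beyond the scatter) and not a step within the scatter. The two groups have the same atoms, and no ring, donor, acceptor or charge differs, so the joining of the chain is the only structural difference that goes with this rise in the amount of compound needed. No measurement bears on why the number moves in this way.

As far as these compounds go, it remains open whether the step follows the loss of the branch in isopropyl or the length reached by propyl, and ethyl, tert-butyl or cyclopropyl at this position would help to separate the two. Also open, from the compounds shown here alone, is whether the same swap would give a step of similar size on another core, such as that of compound 3, since one pair of compounds cannot show this.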